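This account rests on a few compounds, and the source may have more. Where it says the series, first, only, none or still open, it means among the compounds named here.

Among the measured compounds shown here, in an ADME assay on BHK-21 cells (Mesocricetus auratus) for cytotoxicity, read by MTT assay, with a stated time of 72 h (on this read-out higher numbers stand for lower toxicity in this test and lower numbers for higher toxicity in this test), compound 1 `Cc1ccc(C2CC(c3ccccc3)=NN2c2ccc(S(N)(=O)=O)cc2)cc1` gives 7000 nM and compound 2 `Cc1cccc(C2CC(c3ccc(Oc4ccccc4)cc3)=NN2c2ccc(S(N)(=O)=O)cc2)c1` gives 8000 nM with no gap beyond the usual scatter, so compound 2 stands level with the only other measured number. Compound 3 `Cc1cccc(C2CC(c3ccccc3)=NN2c2ccc(S(N)(=O)=O)cc2)c1` carries hydrogen in place of phenoxy on an aromatic carbon, para to a large group, and hydrogen in place of phenoxy on an aromatic carbon is the whole of what separates it from compound 2. For the measured compounds named here, no pair of measured compounds shows this kind of change in this assay so the expectation rests on compound 2 at 8000 nM and on the narrow spread of the two numbers. No shift beyond the scatter is expected in either direction. The estimated move is a 1.1-fold lower number from compound 2 to compound 3 (0.06 log units; within the scatter) and it is expected to stay within the scatter. For compound 3 the expected value is 7000 nM with an estimated range from 3000 nM to 16000 nM as its likely span.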

Compound 3, half-maximal cytotoxic concentration: 25000 nM
Beside the measured number, compound 3's estimate is 3.6-fold (0.55 log units) below it; measured number outside the range, above it.
By their numbers in this assay, from the lowest: compounds 1 and 2 (each within the scatter of the next); then compound 3.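

In this assay, the aromatic carbon para to a large group proves to matter: hydrogen in place of phenoxy gives a 3.1-fold higher number from compound 2 to compound 3 (0.49 log units; beyond the scatter), so with 3-methylphenyl held fixed, the compound carrying phenoxy shows the higher toxicity in this test. The saturated ring carbon matters as well, since 3-methylphenyl in place of 4-methylphenyl gives a 3.6-fold higher number from compound 1 to compound 3 (0.55 log units; beyond the scatter), with the compound carrying 3-methylphenyl showing the lower toxicity in this test. Both modest steps lie beyond the scatter and end at compound 3, which stands apart from the other two compounds.

Nothing measured here accounts for either step. On these data alone, whether a methoxy group or an amine on that aromatic carbon would give a number nearer that of compound 2 or that of compound 3 remains open.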